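Chain shortening in an acylguanidine series

This account rests on a few compounds, and the source may have more. Where it says the series, first, only, none or still open, it means among the compounds named here.

Measured compounds:
- compound 1, `CCCCCCNC(=O)/N=C(\N)NCCCc1sc(N)nc1C`, 85.1 nM
- compound 2, `Cc1nc(N)sc1CCCN/C(N)=N/C(=S)N[C@H](C)c1ccccc1`, 372 nM

In a functional assay on HEK293T cells for agonist activity at histamine H2 receptor (Homo sapiens), read by beta-arrestin recruitment (a higher number here means that more compound is needed for the effect, a lower number that less compound is needed), compound 1 gives the lowest of the two numbers. Within the data shown here, compound 2 gives a higher number in this assay, and the gap between the two values lies beyond the usual scatter; no single-point step connects them, so only the two values are known.

Compound 3, `CCCCCNC(=O)/N=C(\N)NCCCc1sc(N)nc1C`, remains to be measured in this assay. It differs from compound 1 by hydrogen in place of methyl on a saturated chain carbon, five bonds along the chain from an amide-type nitrogen. Among the measured compounds shown here, no measured pair shows a change of this kind, so the size of the step is open. Removing one carbon from the saturated chain is expected to move the number only a little, if at all, with any shift more likely toward a higher number than a lower one. Compound 3 is therefore expected to give 110 nM in this assay, with a range from 50 nM to 250 nM. The step of a 1.3-fold higher number from compound 1 to compound 3 (0.11 log units; within the scatter) is estimated to stay close to the scatter.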

Compound 3, half-maximal effective concentration: 178 nM
Compound 3: the middle estimate sits 1.6-fold (0.21 log units) below what was measured; low and high end bracket the measured number.
By their numbers in this assay, from the lowest: compound 1; then compound 3; then compound 2.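

In this assay, among these compounds, hydrogen in place of methyl on a saturated chain carbon, five bonds along the chain from an amide-type nitrogen, gives a 2.1-fold higher number from compound 1 to compound 3 (0.32 log units; beyond the scatter) as the first single-point step. The outer end of this chain is therefore not a silent position: removing one carbon registers beyond the scatter, though the step is modest and points toward needing more compound. No measured property accompanies this step, so the data offer nothing on what lies behind it.

Going by these compounds, a single step gives no slope, so it remains open whether a butyl or propyl chain would continue in the same direction or a heptyl chain would reverse it. Also open, on these data alone, is how an amine or a hydroxyl at the chain end would compare with the hexyl chain of compound 1.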